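A longer chain for compound 2: what compound 3 may show

The source may hold more compounds than are shown below. What is called first, only, known or untested is meant among the compounds shown, and "the series" means these compounds.

Two measured compounds share one core and differ in a single halogen on an aromatic carbon. Compound 1 `CCC(=O)N1CCN(S(=O)(=O)c2ccc(Cl)cc2)CC1` carries chloro; in a functional assay on the whole organism with Mus musculus as the target (on this read-out higher numbers stand for an effect only at larger amounts of compound and lower numbers for an effect already at smaller amounts), compound 1 gives only a limit, > 0.1 mg/kg, and not a number. Compound 2 `CCC(=O)N1CCN(S(=O)(=O)c2ccc(F)cc2)CC1` carries fluoro in its place, and in this assay compound 2 gives 0.01 mg/kg. The measured step of an at least 10-fold lower number from compound 1 to compound 2 (1.00 log units; beyond the scatter) is the only one shown, so compound 2 holds the only number in this assay, the remaining value being the limit (the limit of > 0.1 mg/kg in this assay, at which 1 of the 2 values shown sits).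

Compound 3 `CCCCCC(=O)N1CCN(S(=O)(=O)c2ccc(F)cc2)CC1` keeps the fluoro of compound 2 and alters the chain instead: propyl in place of hydrogen on a saturated chain carbon, two bonds along the chain from a carbonyl carbon. Among the compounds with values here, no measured step touches this part of the molecule; the one known step concerns fluoro in place of chloro on an aromatic carbon, not a saturated chain carbon two bonds along the chain from a carbonyl carbon. The expectation therefore rests on compound 2 alone and carries a wide range. Compound 3 is estimated at 0.02 mg/kg, expected between 0.003 mg/kg and 0.15 mg/kg. That estimate means an expected step of a 2.0-fold higher number from compound 2 to compound 3 (0.30 log units; within the scatter), with no measured ground for a direction.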

Compound 3, minimum effective dose: 1 mg/kg
Compound 3: middle estimate off by 50-fold (1.70 log units), on the low side; the whole stated range lies below it.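

The chain proved to be far from a silent part of the molecule: in this assay, propyl in place of hydrogen on a saturated chain carbon, two bonds along the chain from a carbonyl carbon, gave a 100-fold higher number from compound 2 to compound 3 (2.00 log units; beyond the scatter), a large step well beyond the scatter. The earlier compounds had shown the read-out responding only to the halogen on the aromatic carbon, whereas compound 3 keeps the fluoro of compound 2 and still needs a much larger dose, so the fluoro alone does not secure an effect at small amounts. Nothing shown gives a reason for the size of this step.

On these data alone, with only the propanoyl and pentylcarbonyl chains in view, it remains open whether the number climbs gradually with chain length or jumps at one point, as a butanoyl chain could indicate, and whether a branched isopropyl group or a chain ending in an amine or a carboxylic acid would be tolerated at this carbon. As far as these compounds go, it also remains open whether the longer chain has the same effect when chloro takes the place of fluoro on the aromatic carbon.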